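Cyclohexyl Amide Follows a Dimethoxyphenyl Limit

The compounds below may be only part of what the source reports. "The series", "measured", "known", "first", "only" and "open" are said of these compounds alone.

Compound 1 `COc1ccc(C(=O)Nc2cc(-c3ccccc3)nn2-c2ccccc2)cc1` gives 420 nM in an assay on HEK293 cells for displacement of a labelled ligand from metabotropic glutamate receptor 5 (Rattus norvegicus); on this read-out lower numbers stand for stronger inhibition and higher numbers for weaker inhibition.
Compound 2 `COc1cc(OC)cc(C(=O)Nc2cc(-c3ccccc3)nn2-c2ccccc2)c1` gives > 10000 nM in this assay, which is a limit of the assay and not a number.

Compound 2 stands at the weak end of what has been measured: its value is a limit, the one at the limit of > 10000 nM in this assay, at which 1 of the 2 values shown sits. For the measured compounds named here, the only measured step, an at least 23-fold higher number from compound 1 to compound 2 (1.37 log units; beyond the scatter), ran toward weaker binding. Compound 3 `O=C(Nc1cc(-c2ccccc2)nn1-c1ccccc1)C1CCCCC1` takes the change (cyclohexyl in place of 3,5-dimethoxyphenyl on a carbonyl carbon). Going by the values given here, no measured step involves a cyclohexyl, so this step is uncertain; the single measured step shows that the group on the carbonyl carbon can shift the read-out far, and compound 1 holds the only value that is not a limit. A return toward a measurable value is expected, namely an at least 3.3-fold lower number from compound 2 to compound 3 (0.52 log units; beyond the scatter) in this assay. Compound 3 is estimated at 3000 nM, with a range from 600 nM to 15000 nM.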

Compound 3, inhibition constant: 10100 nM
Beside the measured number, compound 3's estimate is 3.4-fold (0.53 log units) below it; measured number inside the range.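

The change to cyclohexyl in place of 4-methoxyphenyl on the carbonyl carbon brings a 24-fold higher number from compound 1 to compound 3 (1.38 log units; beyond the scatter) in this assay, so a large loss at this place is not confined to the dimethoxyphenyl group and also appears with a non-aromatic ring that has no oxygen. Among the three compounds, compound 1 is now the strongest, with both of its printed steps beyond the scatter. The step between compound 2 and compound 3 cannot be read, and the value of compound 2 remains a limit of the assay and not a number: the limit of > 10000 nM in this assay, at which 1 of the 3 values shown sits.

The compounds shown do not separate the methoxy group of compound 1 from the aromatic ring that carries it. On these data alone, whether an unsubstituted phenyl, a 4-fluorophenyl or a pyridine on the carbonyl carbon would return toward compound 1 stays open.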